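One Ring Swapped from Compound 2 to Compound 4

A few compounds are considered here, and "the series" means these few. Any claim that something is new, unique, unknown or untested is made for them only; others in the source may bear on it.

Within the data shown here, in an ADME assay on WI-38 cells (Homo sapiens) for cytotoxicity, read by MTT assay, with a stated time of 72 h (a lower number here means a stronger inhibitor, a higher number a weaker inhibitor), compound 2 `CN(C)CCn1cnnc1-c1cc(Oc2ccc(NC(=O)Nc3ccc(Cl)c(C(F)(F)F)c3)cc2F)ccn1` gives 3760 nM, the lowest number measured so far, while compound 1 `Cn1cnnc1-c1cc(Oc2ccc(NC(=O)Nc3cccc(C(F)(F)F)c3)cc2F)ccn1` gives 12600 nM. Compound 3 `CN(C)CCn1cnnc1-c1cc(Oc2ccc(NC(=O)Nc3ccccc3C(F)(F)F)cc2F)ccn1` gives > 50000 nM, which is a limit of the assay and not a number. Compound 4 `CN(C)CCn1cnnc1-c1cc(Oc2ccc(NC(=O)Nc3ccc(F)c(F)c3)cc2F)ccn1` carries one change from compound 2: 3,4-difluorophenyl in place of 4-chloro-3-(trifluoromethyl)phenyl on an amide-type nitrogen. In words, 3,4-difluorophenyl stands in place of 4-chloro-3-(trifluoromethyl)phenyl on an amide-type nitrogen. Among the measured compounds shown here, only one measured step replaces that same group, and it was large: an at least 13-fold higher number from compound 2 to compound 3 (1.12 log units; beyond the scatter). That single step points to a higher number, though a more modest rise is expected here. The expected size is a 3.2-fold higher number from compound 2 to compound 4 (0.50 log units; beyond the scatter). Compound 4 is estimated at 12000 nM, with an expected range of 4000 nM to 40000 nM.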

Compound 4, half-maximal inhibitory concentration: > 50000 nM
Compound 4 ended at the assay's limit (the forecaster's own chance of this, stated with the estimate: 15%); at least 4.1-fold (0.61 log units) between middle value and limit.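

In this assay, replacing the 4-chloro-3-(trifluoromethyl)phenyl on the amide-type nitrogen with 3,4-difluorophenyl also gives a large change: an at least 13-fold higher number from compound 2 to compound 4 (1.12 log units; beyond the scatter). Both replacements shown now raise the number, so the lower number of compound 2 no longer rests on a single step. Compound 3 and compound 4 cannot be ordered, as each value is a limit of the assay: the limit of > 50000 nM in this assay, at which 2 of the 4 values shown sit.

On these data alone, a plain phenyl or a phenyl carrying chlorine alone remains open at this position on the same core. As far as these compounds go, it also remains open whether either would keep the number of compound 2.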